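This account rests on a few compounds, and the source may have more. Where it says the series, first, only, none or still open, it means among the compounds named here.

In a functional assay on HL-60 cells (Homo sapiens) for inhibition, read by CCK-8 assay, with a stated time of 48 h, tested at 20 uM (a lower number here means less inhibition of growth, a higher number more inhibition of growth at the concentration tested), compound 1 (`N#C/C(=C\c1ccccc1OS(=O)(=O)c1ccc(Cl)cc1)C(=O)Nc1nnc(Cc2ccccc2)s1`) gives 26% and compound 2 (`Cc1ccc(S(=O)(=O)Oc2ccccc2/C=C(\C#N)C(=O)Nc2nnc(Cc3ccc(Cl)cc3)s2)cc1`) gives 15% while compound 3 (`N#C/C(=C\c1ccccc1OS(=O)(=O)c1ccccc1[N+](=O)[O-])C(=O)Nc1nnc(Cc2ccc(Cl)cc2)s1`) gives 19% so compound 3 sits within the usual scatter of both others and these numbers do not separate the three. Compound 4 (`N#C/C(=C\c1ccccc1OS(=O)(=O)c1ccc(Cl)cc1)C(=O)Nc1nnc(Cc2ccc(Cl)cc2)s1`) has not yet been measured. It differs from compound 3 by one exchange (4-chlorophenyl in place of 2-nitrophenyl on a sulfonyl sulfur) with 4-chlorophenyl in place of 2-nitrophenyl on a sulfonyl sulfur. Going by the values given here, the only measured step at this place (a number 4 percentage points higher from compound 2 to compound 3 (within the scatter)) brought in 2-nitrophenyl in place of 4-methylphenyl and stayed within the scatter. Compound 1 already carries the entering (4-chlorophenyl)sulfonyl group, and the value of compound 1 (26%) is also within the scatter of compound 3. No step beyond the scatter is therefore expected in this assay and the expected change (a number 2 percentage points higher from compound 3 to compound 4 (within the scatter)) is small. For compound 4 the estimated value is 21% with an expected range from 10% to 33% in this read-out.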

Compound 4, percent growth inhibition at one concentration: 15%
For compound 4 the middle estimate is 6 percentage points above the measured one, and the stated range covers the measured number.
By their numbers in this assay, from the lowest: compounds 2, 4, 3 and 1 (each within the scatter of the next, the first and the last beyond it).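

In this assay the exchange at the sulfonyl sulfur gives a number 4 percentage points lower from compound 3 to compound 4 (within the scatter) and chloro in place of methyl on an aromatic carbon gives no change at the digits printed from compound 2 to compound 4 (within the scatter), so 4-chlorophenyl on the sulfonyl sulfur is not separated from either of the other two groups tested there. Going by these compounds alone, the only step here beyond the scatter lies outside that group: chloro in place of hydrogen on an aromatic carbon gives a number 11 percentage points lower from compound 1 to compound 4 (beyond the scatter), a modest loss of growth inhibition. Nothing shown explains why this step is larger than the others.

Going by these compounds, it remains open whether an aromatic ring carrying an amine or a carboxylic acid on the sulfonyl sulfur would move the number beyond the scatter. A longer chain in place of the aromatic ring at that position is equally untested in the compounds shown here.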